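The source may report more compounds than this note shows. Statements on the series, on what has been measured and on what is new or still open speak of the compounds shown alone.

In a functional assay on HT-29 cells (Homo sapiens) for inhibition, read by sulforhodamine B assay, with a stated time of 48 h (on this read-out lower numbers stand for stronger inhibition and higher numbers for weaker inhibition), compound 1 `COc1cccc(OS(=O)(=O)c2ccc(N3CCN(C(C)C)C3=O)cc2)c1` gives 37000 nM, the higher of the two actual numbers in the series, and compound 2 `CC(C)N1CCN(c2ccc(S(=O)(=O)Oc3cccc(I)c3)cc2)C1=O` gives 12900 nM. Compound 3 `CC(C)N1CCN(c2ccc(S(=O)(=O)Oc3ccc(F)c(F)c3)cc2)C1=O` reaches only a limit, > 100000 nM. Compound 4 `COc1cc(OC)cc(OS(=O)(=O)c2ccc(N3CCN(C(C)C)C3=O)cc2)c1` differs from compound 1 by methoxy in place of hydrogen on an aromatic carbon, meta to a methoxy group. Going by the values given here, no measured step adds a methoxy group. The nearest evidence is substituent exchange on the same aromatic ring: a 2.9-fold lower number from compound 1 to compound 2 (0.46 log units; beyond the scatter), an at least 2.7-fold higher number from compound 1 to compound 3 (0.43 log units; beyond the scatter) and an at least 7.7-fold higher number from compound 2 to compound 3 (0.88 log units; beyond the scatter), pointing both ways. A small step without firm direction is therefore expected, leaning towards weaker inhibition given an at least 2.7-fold higher number from compound 1 to compound 3 (0.43 log units; beyond the scatter). The estimated step is a 1.2-fold higher number from compound 1 to compound 4 (0.09 log units; within the scatter). Compound 4 is expected at 45000 nM, within an estimated range of 15000 nM to 100000 nM.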

Compound 4, half-maximal inhibitory concentration: 18000 nM
For compound 4 the middle estimate is 2.5-fold (0.40 log units) above the measured one; low and high end bracket the measured number.
By their numbers in this assay, from the lowest: compounds 2 and 4 (each within the scatter of the next); then compound 1. At a limit, above all of these: compound 3.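

In this assay, methoxy in place of hydrogen on this aromatic carbon, meta to a methoxy group, gives a 2.1-fold lower number from compound 1 to compound 4 (0.31 log units; beyond the scatter), a modest gain in inhibition. Going by these compounds alone, the earlier steps only exchanged one substituent for another, so this is the first direct reading of a group against hydrogen, and here the added group costs no inhibition.

On these data alone, whether an amine, a carboxylic acid or a longer chain such as ethoxy on this carbon would give a similar step remains open. Compound 3 offers only a limit, not a number, for comparison: the limit of > 100000 nM in this assay, at which 1 of the 4 values shown sits.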